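Swapping furan for thiophene on the ketone of compound 3

This account rests on a few compounds, and the source may have more. Where it says the series, first, only, none or still open, it means among the compounds named here.

Of the compounds shown here, three sharing one core have been tested. Compound 1 `COc1ccc(C(=O)/C=C/c2nc3ccccc3cc2-c2ccc(OC)cc2)cc1` gives 8500 nM in a functional assay on A549 cells (Homo sapiens) for antiproliferative activity, read by XTT assay, with a stated time of 72 h (on this read-out higher numbers stand for weaker inhibition and lower numbers for stronger inhibition), compound 2 `COc1ccc(-c2cc3ccccc3nc2/C=C/C(=O)c2ccc(OC)cc2OC)cc1` gives 7990 nM, and compound 3 `COc1ccc(-c2cc3ccccc3nc2/C=C/C(=O)c2ccco2)cc1` gives 6130 nM. Compound 3 holds the lowest of the three numbers, yet the steps of a 1.4-fold lower number from compound 1 to compound 3 (0.14 log units; within the scatter) and a 1.3-fold lower number from compound 2 to compound 3 (0.12 log units; within the scatter) are both within the scatter, as is a 1.1-fold lower number from compound 1 to compound 2 (0.03 log units; within the scatter). Compound 4 `COc1ccc(-c2cc3ccccc3nc2/C=C/C(=O)c2cccs2)cc1` differs from compound 3 by thiophen-2-yl in place of furan-2-yl on a carbonyl carbon. Among the measured compounds shown here, no measured step bears directly on this exchange; the steps that touch the carbonyl carbon were all small. A step of about a 1.1-fold lower number from compound 3 to compound 4 (0.05 log units; within the scatter) is therefore expected, nothing beyond the scatter. Compound 4 is estimated at 5500 nM, within 2500 nM to 12000 nM.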

Compound 4, half-maximal inhibitory concentration: 920 nM
Compound 4: middle estimate off by 6.0-fold (0.78 log units), on the high side, outside the stated range (below it).
By their numbers in this assay, from the lowest: compound 4; then compounds 3, 2 and 1 (each within the scatter of the next).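

In this assay the group on this carbonyl carbon turns out to matter: a 6.7-fold lower number from compound 3 to compound 4 (0.82 log units; beyond the scatter) shows that replacing the ring oxygen of furan-2-yl with sulfur can move the number beyond the scatter. Thiophen-2-yl also stands clear of the aryl groups, with an 8.7-fold lower number from compound 2 to compound 4 (0.94 log units; beyond the scatter) and a 9.2-fold lower number from compound 1 to compound 4 (0.97 log units; beyond the scatter), although compounds 1, 2 and 3 lie within the scatter of one another. Nothing measured here explains the gain from this exchange.

Going by these compounds, whether a thiophen-2-yl carrying an amine or a carboxylic acid would keep this lower number remains open.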